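Swapping phenyl for amino on a purine carbocyclic analogue

The compounds below may be only part of what the source reports. "The series", "measured", "known", "first", "only" and "open" are said of these compounds alone.

In an ADME assay on L1210/0 cells (Mus musculus) for cytotoxicity, with a stated time of 48 h (on this read-out higher numbers stand for weaker inhibition and lower numbers for stronger inhibition), compound 2 `OC[C@H]1C[C@@H](Cn2cnc3c(-c4ccccc4)ncnc32)c2ccccc21` gives 28100 nM, the higher of the two numbers shown, though its neighbour compound 3 `C=C(Br)[C@H]1O[C@@H](n2cnc3c(N)ncnc32)[C@@H](O)[C@H]1O` with 25000 nM sits within the scatter, so the two cannot be ranked. Compound 1 `O[C@H]1C[C@@H](Cn2cnc3c(-c4ccccc4)ncnc32)c2ccccc21` reaches only the assay limit of > 200000 nM. Going by the values given here, the one measured step, an at least 7.1-fold lower number from compound 1 to compound 2 (0.85 log units; beyond the scatter), concerns a change on the saturated ring, not the aromatic core. Compound 4 `Nc1ncnc2c1ncn2C[C@@H]1C[C@H](CO)c2ccccc21` differs from compound 2 by amino in place of phenyl on an aromatic carbon. Among the compounds with values here, no measured step covers this exchange; compound 3, which carries amino at that place, shows only a similar number. A step of a 1.1-fold higher number from compound 2 to compound 4 (0.03 log units; within the scatter) is therefore expected, within the scatter, and compound 4 is estimated at 30000 nM, between 5000 nM and 180000 nM.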

Compound 4, half-maximal inhibitory concentration: > 200000 nM
Compound 4 was reported as a limit; the forecaster's own chance of this, stated with the estimate: 25%; middle value at least 6.6-fold (0.82 log units) from the limit.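

In this assay, amino in place of phenyl on this aromatic carbon gives an at least 7.1-fold higher number from compound 2 to compound 4 (0.85 log units; beyond the scatter). So this position on the aromatic core also affects the read-out, not only the saturated ring changed in the earlier step, and here the change goes towards weaker inhibition. The value of compound 4 is a limit, not a number: the limit of > 200000 nM in this assay, at which 2 of the 4 values shown sit.

On these data alone, it remains open whether a methyl group or a thiophene ring at this place would keep a number like that of compound 2. As far as these compounds go, it is also open whether a substituted phenyl, such as one carrying a methoxy group, would give a lower number.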